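A Methyl Removed From an Aryl Ether

The source may hold more compounds than are shown below. What is called first, only, known or untested is meant among the compounds shown, and "the series" means these compounds.

Of the compounds shown here, two of a shared core have been measured in a functional assay on M14 cells (Homo sapiens) for inhibition, read by sulforhodamine B assay, with a stated time of 48 h; a lower number here means a stronger inhibitor of growth, a higher number a weaker inhibitor of growth. Compound 2, with structure `COc1cc(-c2nn(-c3cccc(NC(=O)Nc4cc(C(F)(F)F)cc(C(F)(F)F)c4)c3)cc2-c2ccncc2)ccc1Cl`, gives 808 nM in this assay. Compound 1, with structure `O=C(Nc1cccc(-n2cc(-c3ccncc3)c(-c3ccc(Cl)c(O)c3)n2)c1)Nc1cccc(C(F)(F)F)c1`, gives 1400 nM in this assay; the two values lie within the usual scatter of such measurements, so neither compound can be called the stronger inhibitor.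

Compound 3, with structure `O=C(Nc1cccc(-n2cc(-c3ccncc3)c(-c3ccc(Cl)c(O)c3)n2)c1)Nc1cc(C(F)(F)F)cc(C(F)(F)F)c1`, has not yet been measured. It differs from compound 2 in one place: hydrogen in place of methyl on an oxygen on an aromatic ring. Among the compounds with values here, no pair of measured compounds shows this change alone, so its effect is unknown here. Compound 1 also carries the hydroxy group, but it differs from compound 2 in a second place as well, and its value sits within the scatter of compound 2.

Compound 3 is therefore expected to lie near compound 2, with a step of a 1.2-fold higher number from compound 2 to compound 3 (0.09 log units; within the scatter), no further than the scatter. The estimate for compound 3 is 1000 nM, between 400 nM and 2500 nM.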

Compound 3, concentration for 50% growth inhibition: 607 nM
Compound 3: middle estimate off by 1.6-fold (0.22 log units), on the high side, and the stated range covers the measured number.
By their numbers in this assay, from the lowest: compounds 3, 2 and 1 (each within the scatter of the next, the first and the last beyond it).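

In this assay, replacing methoxy with hydroxy on the 4-chloro-3-methoxyphenyl group gives a 1.3-fold lower number from compound 2 to compound 3 (0.12 log units; within the scatter) and so shows no readable difference, which means this position accepts either group in these compounds. Within the data shown here, with the hydroxy group held in place, a second trifluoromethyl group gives a 2.3-fold lower number from compound 1 to compound 3 (0.36 log units; beyond the scatter) as the only step here beyond the scatter, though it is a modest one. Nothing available here explains the size of either step.

Going by these compounds, what an amine, a fluorine atom or an ethoxy group would do at this position stays open, as does whether an oxygen is needed there at all. The step for the second trifluoromethyl group is read only with hydroxy present, so whether it holds with methoxy is also unknown.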